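The source may hold more compounds than are shown below. What is called first, only, known or untested is meant among the compounds shown, and "the series" means these compounds.

Of the compounds shown here, three have so far been measured in an in vitro assay on cells for inhibition of Amine oxidase [flavin-containing] B (Homo sapiens), read by Amplex Red, with a stated time of 15 min; on this read-out higher numbers stand for weaker inhibition and lower numbers for stronger inhibition. Compound 1, `O=C(/C=C(O)/C=C/c1ccc(O)c(O)c1)c1ccccc1O`, gives 654 nM. Compound 2, `O=C(/C=C/C=C/c1ccc([N+](=O)[O-])cc1)c1cc(Cl)ccc1O`, gives 1080 nM, and compound 3, `COc1ccc(/C=C/C=C/C(=O)c2ccccc2O)cc1`, gives 1810 nM. Compound 1 thus holds the lowest number of the three; its gap to compound 2 lies within the usual scatter, so those two cannot be ranked against each other, while its gap to compound 3 lies beyond the scatter.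

The next compound, compound 4, `O=C(/C=C(O)/C=C/c1ccc(O)cc1)c1ccccc1O`, has not yet been measured in this assay. It differs from compound 1 in a single place: hydrogen in place of hydroxy on an aromatic carbon. The change removes one hydroxy group from an aromatic carbon of a six-membered aromatic ring of carbon only, ortho to a hydroxy group and meta to a large group, and leaves the rest of the molecule untouched.

Among the measured compounds shown here, no step between two measured compounds that differ in only one place has been recorded, so there is no direct precedent for this change within the set. A small step toward weaker inhibition, of about a 1.5-fold higher number from compound 1 to compound 4 (0.16 log units; within the scatter) and likely not beyond the scatter, is expected. Compound 4 is therefore estimated to give 950 nM in this assay, with a range from 350 nM to 2600 nM.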

Compound 4, half-maximal inhibitory concentration: 26.5 nM
Compound 4: the middle estimate sits 36-fold (1.55 log units) above what was measured; measured number below the stated range.
By their numbers in this assay, from the lowest: compound 4; then compounds 1, 2 and 3 (each within the scatter of the next, the first and the last beyond it).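

Among the compounds shown here, putting hydrogen in place of the hydroxy group on this aromatic carbon gives a 25-fold lower number from compound 1 to compound 4 (1.39 log units; beyond the scatter) in this assay and provides the first direct comparison of two compounds that differ in only one place. It shows that inhibition in this pair is highly sensitive to what stands at this position: with a hydroxy group there, ortho to a second hydroxy group and meta to a large group, the number is much higher than with hydrogen. No measurement shown explains why this single change has so large an effect.

This one pair cannot show whether hydrogen is especially favorable here or whether other small groups would serve as well, so a fluorine atom or an amine on the same carbon would be an informative comparison. It also leaves open whether the remaining hydroxy group on this ring matters in its own right, and whether the same change would have a similar effect in compounds with a different core.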